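The source may hold more compounds than are shown below. What is called first, only, known or untested is meant among the compounds shown, and "the series" means these compounds.

Measured so far:
compound 1, `COc1ccc2nc(C)cc(OCCNc3cc(C)cc(C)c3)c2c1`: 6.93
compound 2, `COc1ccc2nc(C)cc(OCC(=O)Nc3ccccc3)c2c1`: 4.28

Both were read in a physicochemical assay for lipophilicity, read by HPLC, in phosphate buffer, measured as chromatographic lipophilicity, at pH 7.4; a lower number here means a more polar compound, a higher number a more lipophilic compound. Compound 1 gives 6.93 there, and compound 2 gives 4.28. Among the compounds with values here, compound 2 thus stands at the lower of the two numbers; compound 1 sits far above it, beyond the scatter, but the two structures differ in more than one place, so no single step connects them and the gap cannot be assigned to any one change.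

Compound 3 is `COc1ccc2nc(C)cc(OCC(=O)Nc3ccc(F)cc3)c2c1` and is not yet measured in this assay. Against compound 2 the difference is confined to one spot: fluoro in place of hydrogen on an aromatic carbon. The fluoro enters on an aromatic carbon of a six-membered aromatic ring of carbon only, para to a large group; read one bond further out, phenyl becomes 4-fluorophenyl and anilino becomes (4-fluorophenyl)amino.

Within the data shown here, no measured pair shows this exchange, so the direction has to be estimated. A small upward step, a number 0.17 log units higher from compound 2 to compound 3 (within the scatter), is expected in this assay, of a size near the usual scatter rather than clearly beyond it. Compound 3 is accordingly expected to give about 4.45, within a range from 4.2 to 4.7.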

Compound 3, distribution coefficient: 4.49
Compound 3: middle estimate off by 0.04 log units, on the low side, within the range that was stated.
By their numbers in this assay, from the lowest: compounds 2 and 3 (each within the scatter of the next); then compound 1.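

Fluoro in place of hydrogen on an aromatic carbon, para to a large group, gives a number 0.21 log units higher from compound 2 to compound 3 (within the scatter) in this assay and is the first exchange in the series that can be read at a single place. Phenyl to 4-fluorophenyl therefore does not separate compound 2 from compound 3 in this read-out, and the two stand as one level of the series at this position. Nothing at hand bears on the origin of this step.

As far as these compounds go, whether a different group on the same aromatic carbon, such as chloro, methoxy or a dimethylamino group, would carry the number beyond the scatter remains open, as does the outcome of fluoro on another carbon of that ring. It also remains open how the link between the core and this ring contributes, since a single-place comparison with an amine, a carboxylic acid or a longer chain there is absent from the compounds shown, and the difference from compound 1 cannot be assigned to any one part.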